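Adding a hydroxy to compound 3

The compounds below may be only part of what the source reports. "The series", "measured", "known", "first", "only" and "open" are said of these compounds alone.

Compound 1 `CCCCC[C@H](C[C@H](O)C[C@@H]1CC=CC(=O)O1)OC` gives 22900 nM
Compound 2 `CCCCC[C@@H](C[C@H](O)C[C@H]1CC=CC(=O)O1)OC` gives 53700 nM
Compound 3 `CCCCC[C@H](CCC[C@H]1CC=CC(=O)O1)OC` gives 17100 nM

These values come from a functional assay on A2780 cells (Homo sapiens) for cytotoxicity, read by MTT assay, with a stated time of 24 h; on this read-out lower numbers stand for stronger inhibition and higher numbers for weaker inhibition. In this assay compound 3 at 17100 nM lies within the usual scatter of compound 1 , and beyond the scatter on the lower side of compound 2 . Compound 4 `CCCCC[C@H](C[C@H](O)C[C@H]1CC=CC(=O)O1)OC` differs from compound 3 by hydroxy in place of hydrogen on a saturated chain carbon bound to two saturated chain carbons. Compound 1 and compound 2 carry that hydroxy too, so they are the nearest guides. For the measured compounds named here, the one measured step between them is a 2.3-fold higher number from compound 1 to compound 2 (0.37 log units; beyond the scatter), modest but beyond the scatter, and it comes with the fact that compounds 1 and 2 differ only in the configuration as drawn. Compound 4 has its own configuration, so its value could plausibly fall anywhere near that span. A small move towards a higher number is therefore expected, quite possibly no larger than the scatter. The estimated change is a 1.8-fold higher number from compound 3 to compound 4 (0.24 log units; within the scatter) as an expectation only. For compound 4 the expected value is 30000 nM, with an estimated range of 13000 nM to 65000 nM.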

Compound 4, half-maximal inhibitory concentration: 44000 nM
Estimate against measurement, compound 4: 1.5-fold (0.17 log units) below; the range from low to high includes it.
By their numbers in this assay, from the lowest: compounds 3, 1, 4 and 2 (each within the scatter of the next, the first and the last beyond it).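

In this assay, for the compounds shown here, hydroxy in place of hydrogen on a saturated chain carbon bound to two saturated chain carbons can now be read directly as a 2.6-fold higher number from compound 3 to compound 4 (0.41 log units; beyond the scatter), a modest step that no earlier pair isolated. Changing one stereocentre at a time stays within the scatter, with a 1.2-fold lower number from compound 2 to compound 4 (0.09 log units; within the scatter) at a saturated chain carbon and a 1.9-fold higher number from compound 1 to compound 4 (0.28 log units; within the scatter) at a saturated ring carbon, while only the change at both centres, a 2.3-fold higher number from compound 1 to compound 2 (0.37 log units; beyond the scatter), goes beyond it. Both single-centre steps are readings of configuration alone: the fact that compounds 1 and 4 differ only in the configuration as drawn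

The compounds shown leave open whether the step from hydrogen to hydroxy would be similar in the other configurations, since it is read in only one. They also leave open how an amine or a fluorine on that saturated chain carbon would compare.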